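Swapping chloro for carboxy in a cytotoxicity series

The compounds below may be only part of what the source reports. "The series", "measured", "known", "first", "only" and "open" are said of these compounds alone.

Compound 1 `CC(=O)Nc1ccc(NC(=O)NCCCCC(c2ccc(F)cc2)c2ccc(F)cc2)cc1`: > 20000 nM, a limit of the assay, not a number
Compound 2 `O=C(NCCCCC(c1ccc(F)cc1)c1ccc(F)cc1)Nc1ccc(Cl)c(C(F)(F)F)c1`: 3150 nM

For the measured compounds named here, in a functional assay on MDA-MB-231 cells (Homo sapiens) for cytotoxicity, read by MTT assay, with a stated time of 48 h (a lower number here means a stronger inhibitor, a higher number a weaker inhibitor), compound 2 gives 3150 nM, the only actual number so far. Compound 3 `O=C(NCCCCC(c1ccc(F)cc1)c1ccc(F)cc1)Nc1ccc(C(=O)O)c(C(F)(F)F)c1` differs from it by one change, carboxy in place of chloro on an aromatic carbon. Going by the values given here, the one measured step bearing on this, an at least 6.3-fold lower number from compound 1 to compound 2 (0.80 log units; beyond the scatter), brought in the chloro that now leaves, so a move back towards weaker inhibition is expected. The estimated size of the move is a 4.8-fold higher number from compound 2 to compound 3 (0.68 log units; beyond the scatter). For compound 3 the expected value is 15000 nM, with an estimated range of 5000 nM to 45000 nM.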

Compound 3, half-maximal inhibitory concentration: > 20000 nM
Compound 3 was reported as a limit; the forecaster's own chance of this, stated with the estimate: 45%; at least 1.3-fold (0.12 log units) between middle value and limit.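

With the trifluoromethyl group kept in place, chloro at this position cannot be exchanged for carboxy without a loss in this assay, which shows an at least 6.3-fold higher number from compound 2 to compound 3 (0.80 log units; beyond the scatter). The earlier step replaced a whole aryl group, whereas this one changes the chloro alone, so the trifluoromethyl group does not hold the effect by itself. The true size of the step stays unknown because compound 3 gives a limit of the assay, not a number: the limit of > 20000 nM in this assay, at which 2 of the 3 values shown sit.

Still open, going by these compounds, is whether a methyl or a fluoro at this position, or a methyl ester or a primary amide in place of the carboxylic acid, would stay closer to compound 2.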